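The compounds below may be only part of what the source reports. "The series", "measured", "known", "first", "only" and "open" are said of these compounds alone.

Working notes on a series sharing one core. Compound 1 `Cc1nc2cc(Br)ccc2nc1Oc1ccc(N)cc1` gives 0.00052 ug/mL in a functional assay on NCI-H460 cells (Homo sapiens) for inhibition, read by sulforhodamine B assay, with a stated time of 72 h; on this read-out lower numbers stand for stronger inhibition and higher numbers for weaker inhibition. Within the data shown here, compound 2 `Cc1nc2cc(Br)ccc2nc1Oc1ccc(C=O)cc1` gives 0.0285 ug/mL in this assay; the step of a 55-fold higher number from compound 1 to compound 2 (1.74 log units; beyond the scatter) is the only measured step in the set. Compound 2 therefore stands at the higher of the two numbers, with compound 1 the nearest point and well beyond the scatter on the stronger side.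

Compound 3 `Cc1nc2cc(Br)ccc2nc1Oc1ccc(/C=N\c2ccc(Cl)cc2)cc1` is not yet measured. Relative to compound 2 the change is a group of 9 heavy atoms (7 carbon, 1 nitrogen, 1 chlorine; one six-membered aromatic ring of carbon only) in place of a group of 2 heavy atoms (1 carbon, 1 oxygen; no ring), on an aromatic carbon. Among the measured compounds shown here, no measured step covers a change of this kind: the step from compound 1 to compound 2 swaps two small groups at the same aromatic carbon and offers no guide to the entering ring-bearing group, so the expected direction is open. Compound 3 is expected to give 0.012 ug/mL in this assay, within 0.002 ug/mL to 0.08 ug/mL, meaning an expected step of a 2.4-fold lower number from compound 2 to compound 3 (0.38 log units; beyond the scatter).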

Compound 3, half-maximal inhibitory concentration: 0.0187 ug/mL
Compound 3: the middle estimate sits 1.6-fold (0.19 log units) below what was measured; low and high end bracket the measured number.
By their numbers in this assay, from the lowest: compound 1; then compounds 3 and 2 (each within the scatter of the next).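

At this aromatic carbon, para to a large group, the ring-bearing group of 9 heavy atoms in place of formyl gives a 1.5-fold lower number from compound 2 to compound 3 (0.18 log units; within the scatter) in this assay, so a far larger group is accommodated here with no change in the number beyond the scatter. The amino group stays apart, with a 36-fold higher number from compound 1 to compound 3 (1.56 log units; beyond the scatter) as a large step that matches the one seen for formyl, and among the three compounds only amino gives a number in the stronger range. No evidence is available that bears on these results.

Going by these compounds, whether the standing of compound 1 carries over to other groups at this carbon, such as hydroxyl, methylamino or acetamide, remains open. On these data alone, the contribution of the chlorine on the entering ring is also open, as is what a methoxy group in its place would give.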